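Purine chloromethylbenzyl series: amino substitution at the six-membered ring

This account rests on a few compounds, and the source may have more. Where it says the series, first, only, none or still open, it means among the compounds named here.

Measured so far in a functional assay on OVCAR-3 cells (Homo sapiens) for cytotoxicity, read by sulforhodamine B assay, with a stated time of 48 h; a lower number here means that less compound is tolerated, a higher number that more compound is tolerated:
compound 1 `ClCc1ccc(Cn2cnc3c(Cl)ncnc32)cc1`, 8910 nM
compound 2 `Nc1nc(Cl)c2ncn(Cc3ccc(CCl)cc3)c2n1`, 22900 nM
compound 3 `ClCc1ccccc1Cn1cnc2c(Cl)ncnc21`, 8910 nM

Compound 1 and compound 3 share the same atoms joined differently; the difference between the two cores is not broken down here. Their values in this assay are level at the digits printed, within the scatter.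

Compound 2 differs from compound 1 by one change, (amino in place of hydrogen on an aromatic carbon), and the step of a 2.6-fold higher number from compound 1 to compound 2 (0.41 log units; beyond the scatter) is modest but beyond the scatter.

Compound 4 `Nc1nc(Cl)c2ncn(Cc3ccccc3CCl)c2n1` has not yet been measured in this assay. It differs from compound 3 by amino in place of hydrogen on an aromatic carbon, the same change at the same place as that from compound 1 to compound 2. Within the data shown here, the step is expected to be about a 2.5-fold higher number from compound 3 to compound 4 (0.39 log units; beyond the scatter), resting on the single earlier instance, because a 2.6-fold higher number from compound 1 to compound 2 (0.41 log units; beyond the scatter) is the only precedent and, level with compound 1 in this assay, compound 3 gives 8910 nM. For compound 4 the expected value in this assay is therefore 22000 nM, with a range from 11000 nM to 45000 nM.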

Compound 4, concentration lethal to 50% of the cells: 46800 nM
Compound 4: middle estimate off by 2.1-fold (0.33 log units), on the low side, and the stated range ends below it.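

In this assay, amino in place of hydrogen on an aromatic carbon gives a 5.3-fold higher number from compound 3 to compound 4 (0.72 log units; beyond the scatter), in the same direction as the earlier step, and the two steps are not told apart: the same change on two cores in this assay, a 2.6-fold higher number (0.41 log units; beyond the scatter) from compound 1 to compound 2 and a 5.3-fold higher number (0.72 log units; beyond the scatter) from compound 3 to compound 4, 2.0-fold (0.31 log units) apart, within the scatter of two such steps. On these two cores the change therefore carries over in direction and, within the scatter, in size. This rests on two pairs in this assay alone and does not show that the step holds on any other core or in any other assay.

From the compounds shown here alone, whether a methylamino or a hydroxyl group on the same aromatic carbon moves the number in the same way remains open. So does the part played by the chloromethyl group, for which a methyl or a hydroxymethyl group in its place would give the comparison.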